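Swapping Methoxy for Fluoro on a Shared Core

The source may report more compounds than this note shows. Statements on the series, on what has been measured and on what is new or still open speak of the compounds shown alone.

Three compounds with one shared core were tested in a functional assay on the whole organism for inhibition, with Mus musculus as the target, at a dose of 10 mg/kg by the oral route; a higher number here means more inhibition at the dose given (going by the name of the read-out), a lower number less inhibition. Compound 1 `Cc1ccc2c(c1)C(=O)/C(=C(\S)N(C)c1ccccc1)C(=O)N2C` gives 20%, compound 2 `CN1C(=O)/C(=C(/S)N(C)c2ccccc2)C(=O)c2cc(Br)ccc21` gives 56% and compound 3 `COc1ccc(N(C)/C(S)=C2/C(=O)c3cc(Cl)ccc3N(C)C2=O)cc1` gives 45%. Compound 3 thus stands second of the three, below compound 2 and well above compound 1, with both gaps beyond the scatter. Within the data shown here, the only measured step, a number 36 percentage points higher from compound 1 to compound 2 (beyond the scatter), alters the core itself rather than the group that changes here. Compound 4 `CN1C(=O)/C(=C(/S)N(C)c2ccc(F)cc2)C(=O)c2cc(Cl)ccc21` differs from compound 3 in one place: fluoro in place of methoxy on an aromatic carbon, so the 4-methoxyphenyl becomes a 4-fluorophenyl. Among the measured compounds shown here, no measured pair shows what this change does, so in this assay a step within the scatter is expected, no change at the digits printed from compound 3 to compound 4 (within the scatter). Compound 4 is therefore estimated at 45%, between 25% and 65%.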

Compound 4, a percentage reported as inhibition, in the whole organism at one dose (the size of the read-out at that dose, not a potency): 54%
Compound 4: middle estimate off by 9 percentage points, on the low side; measured number inside the range.
By their numbers in this assay, from the lowest: compound 1; then compounds 3, 4 and 2 (each within the scatter of the next, the first and the last beyond it).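

In this assay, among these compounds, the change from methoxy to fluoro gives a number 9 percentage points higher from compound 3 to compound 4 (within the scatter) and so offers the first measured look at this position on the aromatic ring. On this chloro-bearing core, the 4-fluorophenyl and the 4-methoxyphenyl cannot be told apart at this dose, even though fluoro has fewer heavy atoms and no hydrogen-bond acceptor. No measurement given here explains this result. Still open, on these data alone, is whether an amine, a carboxylic acid or a longer chain such as butoxy at this position would keep the inhibition. As far as these compounds go, it is also open whether fluoro would behave the same way with bromo in place of chloro on the core.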